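The source may hold more compounds than are shown below. What is called first, only, known or untested is meant among the compounds shown, and "the series" means these compounds.

Compound 1 `CC(=O)NCCN(C)c1cccc(OCCCCN)c1` gives 0.32 in a functional assay on cells for agonist activity at melatonin receptor type 1A (Homo sapiens), read by GTPgammaS binding, with a stated time of 30 min; a lower number here means a smaller maximal response, a higher number a larger maximal response. Compound 2 `CC(=O)NCCN(C)c1cccc(OCCCCNC(=O)Oc2cccc(-c3ccccc3)c2)c1` gives 0.64. Compound 3 `CC(=O)NCCN(C)c1cccc(OCCCCCCNC(=O)Oc2cccc(-c3ccccc3)c2)c1` gives 0.7.

In this assay compound 1 stands lowest of the three, below compound 2 and compound 3 by amounts beyond the usual scatter. Compound 2 and compound 3, which carry a carbamate at the chain end, lie within the scatter of each other. Compound 4 `CC(=O)NCCN(C)c1cccc(OCCCCCCN)c1` differs from compound 1 as follows: 2-aminoethyl in place of amino on a saturated chain carbon, four bonds along the chain from an oxygen on an aromatic ring. For the measured compounds named here, no step between measured compounds isolates this chain extension on the free amine. The account therefore expects the step a number 0.060 higher from compound 1 to compound 4 (within the scatter) to be small, at most a slight rise, staying within or barely beyond the scatter. Compound 4 is estimated at 0.38, with a range from 0.22 to 0.55.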

Compound 4, intrinsic activity: the largest response reached, as a fraction of the reference agonist's: 0.34
The estimate for compound 4 lay 0.040 above the measured number; the range from low to high includes it.
By their numbers in this assay, from the lowest: compounds 1 and 4 (each within the scatter of the next); then compounds 2 and 3 (each within the scatter of the next).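

In this assay the change to 2-aminoethyl in place of amino, on a saturated chain carbon four bonds along the chain from an oxygen on an aromatic ring, gives a step of a number 0.020 higher from compound 1 to compound 4 (within the scatter). With a free amine at the chain end, this extra chain length therefore does not separate the two compounds. No measurement shown here offers an explanation for this result. The compounds shown leave open whether a still longer chain ending in an amine, or a chain ending in a carboxylic acid, would stand apart from compound 1 in this assay.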